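Replacing the ester of compound 3 with a methylpyrazole

The source may hold more compounds than are shown below. What is called first, only, known or untested is meant among the compounds shown, and "the series" means these compounds.

Values in a functional assay on A549 cells (Homo sapiens) for inhibition, read by CCK-8 assay, with a stated time of 48 h; a higher number here means a weaker inhibitor, a lower number a stronger inhibitor:
Compound 1 `COc1cc(-c2ccnc3cc(-c4ccc(C)cc4)nn23)cc(OC)c1OC`: 3 nM
Compound 2 `C=Cc1ccc(-c2cc3nccc(-c4cc(OC)c(OC)c(OC)c4)n3n2)cc1`: 1030 nM
Compound 3 `CCOC(=O)c1ccc(-c2cc3nccc(-c4cc(OC)c(OC)c(OC)c4)n3n2)cc1`: > 10000 nM, a limit

Compound 3 gives no number, only (the limit of > 10000 nM in this assay, at which 1 of the 3 values shown sits). Compound 4 `COc1cc(-c2ccnc3cc(-c4ccc(-c5cnn(C)c5)cc4)nn23)cc(OC)c1OC` differs from it on an aromatic carbon: 1-methyl-1H-pyrazol-4-yl in place of ethoxycarbonyl on an aromatic carbon. Among the compounds with values here, three measured steps bear on this place. Vinyl for methyl gave a 340-fold higher number from compound 1 to compound 2 (2.54 log units; beyond the scatter), ethoxycarbonyl for methyl gave an at least 3300-fold higher number from compound 1 to compound 3 (3.52 log units; beyond the scatter), and ethoxycarbonyl for vinyl gave an at least 9.7-fold higher number from compound 2 to compound 3 (0.98 log units; beyond the scatter). Neither replacement of methyl kept the number of compound 1 at 3 nM, so compound 4 is expected to stay weak. The expected change is an at least 2.5-fold lower number from compound 3 to compound 4 (0.39 log units; beyond the scatter) in this assay, a modest move to a lower number if a number is reported. For compound 4 the estimate is 4000 nM, with an expected range of 500 nM to 20000 nM.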

Compound 4, half-maximal inhibitory concentration: 1150 nM
Compound 4: the middle estimate sits 3.5-fold (0.54 log units) above what was measured; measured number inside the range.
By their numbers in this assay, from the lowest: compound 1; then compounds 2 and 4 (each within the scatter of the next). At a limit, above all of these: compound 3.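

In this assay, compound 3 gives only a limit: the limit of > 10000 nM in this assay, at which 1 of the 4 values shown sits. The 1-methyl-1H-pyrazol-4-yl group gives a measurable number where the ethoxycarbonyl group gave none, with an at least 8.6-fold lower number from compound 3 to compound 4 (0.93 log units; beyond the scatter), and it cannot be told apart from vinyl, with a 1.1-fold higher number from compound 2 to compound 4 (0.05 log units; within the scatter). Against methyl it still loses heavily, with a 380-fold higher number from compound 1 to compound 4 (2.58 log units; beyond the scatter), so none of the three replacements of methyl shown keeps the number of compound 1.

The compounds shown leave open whether ethyl or chlorine at this place would keep that number. They also leave open how an amine or a carboxylic acid would fare here.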